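A few compounds are considered here, and "the series" means these few. Any claim that something is new, unique, unknown or untested is made for them only; others in the source may bear on it.

Measured compounds:
- compound 1 `O=C(/C=C/c1cccc(Br)c1)NNC(=O)c1ccc2c(c1)OCCO2`: 351000 nM
- compound 2 `O=C(/C=C/c1cccc([N+](=O)[O-])c1)NNC(=O)c1ccc2c(c1)OCCO2`: 323000 nM
- compound 3 `Cc1cccc(/C=C/C(=O)NNC(=O)c2ccc3c(c2)OCCO3)c1`: 281000 nM

In an ADME assay on cells (Macrophage) for cytotoxicity, read by MTT assay, with a stated time of 24 h (on this read-out higher numbers stand for lower toxicity in this test and lower numbers for higher toxicity in this test), compound 1 gives 351000 nM and stands highest of the three numbers shown. Its nearest neighbour is compound 2 with 323000 nM, a change of a 1.1-fold lower number from compound 1 to compound 2 (0.04 log units; within the scatter); its furthest is compound 3 with 281000 nM, a change of a 1.2-fold lower number from compound 1 to compound 3 (0.10 log units; within the scatter). The step of a 1.1-fold lower number from compound 2 to compound 3 (0.06 log units; within the scatter) is likewise within the scatter, so the three numbers cannot be told apart on this read-out.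

Compound 4 `COc1cccc(/C=C/C(=O)NNC(=O)c2ccc3c(c2)OCCO3)c1` has not yet been measured in this assay. Its difference from compound 1 is methoxy in place of bromo on an aromatic carbon: the bromo leaves and a methoxy enters, on an aromatic carbon of a six-membered aromatic ring of carbon only.

Within the data shown here, no measured step swaps bromo for methoxy. Among the measured compounds shown here, the steps that bear on it are the three exchanges at the same aromatic carbon, bromo to nitro, bromo to methyl and nitro to methyl, and each stayed within the scatter. On that basis the step of a 1.1-fold lower number from compound 1 to compound 4 (0.04 log units; within the scatter) is expected to stay within the scatter as well, with no direction favoured. Compound 4 is therefore estimated at 320000 nM in this assay, with a range from 200000 nM to 500000 nM.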

Compound 4, half-maximal cytotoxic concentration: 398000 nM
Estimate against measurement, compound 4: 1.2-fold (0.09 log units) below; the range from low to high includes it.
By their numbers in this assay, from the lowest: compounds 3, 2, 1 and 4 (each within the scatter of the next).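

In this assay, a fourth group at this aromatic carbon leaves the picture unchanged, since the exchange from 3-bromophenyl to 3-methoxyphenyl gives a 1.1-fold higher number from compound 1 to compound 4 (0.05 log units; within the scatter), and the comparisons with the other two groups give a 1.2-fold higher number from compound 2 to compound 4 (0.09 log units; within the scatter) and a 1.4-fold higher number from compound 3 to compound 4 (0.15 log units; within the scatter). The last of these is the widest step among the four compounds, yet it is still within the scatter, so all six exchanges now available at this place fail to separate the compounds, even with an entering group that counts a hydrogen-bond acceptor where bromo counts none and that has more heavy atoms than bromo. No accompanying measurement speaks to a cause for this flat result.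

The compounds shown leave open whether any group at this place can move the number beyond the scatter, for instance an amine, a carboxylic acid or a longer chain such as butoxy in place of methoxy. They also leave open whether the same flat result would hold once the core of compound 1 is itself changed elsewhere.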